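Adding a Chloro Group to a Cytotoxicity Lead

The compounds below may be only part of what the source reports. "The series", "measured", "known", "first", "only" and "open" are said of these compounds alone.

Compound 1, `CNC(=O)c1cc(Oc2ccc(NC(=O)c3nn(-c4ccccc4F)c(=O)cc3C)cc2F)ccn1`: in a functional assay on HepG2 cells (Homo sapiens) for cytotoxicity, read by MTT assay, with a stated time of 72 h (a lower number here means a stronger inhibitor, a higher number a weaker inhibitor), compound 1 gives > 40000 nM, a limit of the assay rather than a number.
Compound 2, `Cc1cc(=O)n(-c2ccc(F)cc2)nc1C(=O)Nc1ccc(Oc2ncnc3sccc23)c(F)c1`: in this assay compound 2 gives 12500 nM.
Compound 3, `O=C(Nc1ccc(Oc2ncnc3ccsc23)c(F)c1)c1nn(-c2ccc(F)cc2)ccc1=O`: in this assay compound 3 gives 9160 nM.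

For the measured compounds named here, only two of the three compounds give a number, and the numbers for compound 3 and compound 2 sit within the usual scatter of each other, so neither stands apart. Compound 1 is known only through (the limit of > 40000 nM in this assay, at which 1 of the 3 values shown sits).

Compound 4, `O=C(Nc1ccc(Oc2ncnc3ccsc23)c(F)c1)c1nn(-c2ccc(F)c(Cl)c2)ccc1=O`, differs from compound 3 by chloro in place of hydrogen on an aromatic carbon. No measured pair among these compounds shows a step of this kind. The expected step of a 1.3-fold lower number from compound 3 to compound 4 (0.12 log units; within the scatter) is small, not beyond the scatter, in either direction. Compound 4 is therefore estimated at 7000 nM, with a range from 2500 nM to 20000 nM.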

Compound 4, half-maximal inhibitory concentration: 10600 nM
For compound 4 the middle estimate is 1.5-fold (0.18 log units) below the measured one; low and high end bracket the measured number.
By their numbers in this assay, from the lowest: compounds 3, 4 and 2 (each within the scatter of the next). At a limit, above all of these: compound 1.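

For the compounds shown here, replacing 4-fluorophenyl with 3-chloro-4-fluorophenyl gives the only readable step in this set: in this assay there is a 1.2-fold higher number from compound 3 to compound 4 (0.06 log units; within the scatter). At this place, ortho to a fluoro group, chloro in place of hydrogen therefore produces no change that can be told apart from the scatter. Nothing measured here bears on why this is so.

The compounds shown leave open whether an amine or a carboxylic acid at this same place would shift the number beyond the scatter. They also leave open how chloro would behave here on the core of compound 2.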